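The compounds below may be only part of what the source reports. "The series", "measured", "known", "first", "only" and "open" are said of these compounds alone.

In a functional assay on the whole organism (strain Kunming) for inhibition, with Mus musculus as the target, in the writhing test, at a dose of 40 mg/kg by the oral route (on this read-out higher numbers stand for more inhibition at the one dose given (going by the name of the read-out) and lower numbers for less inhibition), compound 1 `CC(=O)Oc1ccc(-c2ccc(F)cc2F)cc1C(=O)O` gives 0%.
In this assay compound 2 `O=C(Oc1ccc(-c2ccc(F)cc2F)cc1C(=O)O)c1ccccc1` gives 7.97%.
In this assay compound 3 `CC(=O)Oc1ccc(-c2ccc(F)cc2F)cc1C(=O)Nc1ccccc1Cl` gives 11.7%.

Compound 2 stands second highest of the three numbers, yet its gap to compound 3 and its gap to compound 1 both lie within the scatter, so compound 2 cannot be placed in any order against either. Compound 4 `CN1CCN(NC(=O)c2cc(-c3ccc(F)cc3F)ccc2OC(=O)c2ccccc2)CC1` differs from compound 2 by (4-methylpiperazin-1-yl)amino in place of hydroxy on a carbonyl carbon.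

Among the compounds with values here, one measured step bears on this change, since it also replaces hydroxy on the same carbonyl carbon: a number 11.7 percentage points higher from compound 1 to compound 3 (beyond the scatter). The other step, a number 8 percentage points higher from compound 1 to compound 2 (within the scatter), concerns a different carbonyl carbon and offers no guide. Within the data shown here, no measured compound carries (4-methylpiperazin-1-yl)amino, so the expectation rests on that single modest step alone. A rise of similar size is therefore expected, a number 10 percentage points higher from compound 2 to compound 4 (within the scatter), though it may fall within the scatter. Compound 4 is estimated at 18%, with a range from 4% to 32%.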

Compound 4, a percentage reported as inhibition, in the whole organism at one dose (the size of the read-out at that dose, not a potency): 88.3%
Compound 4: middle estimate off by 70.3 percentage points, on the low side; measured number outside the range, above it.
By their numbers in this assay, from the lowest: compounds 1, 2 and 3 (each within the scatter of the next, the first and the last beyond it); then compound 4.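

Swapping the hydroxy on this carbonyl carbon for (4-methylpiperazin-1-yl)amino gives a number 80.3 percentage points higher from compound 2 to compound 4 (beyond the scatter) in this assay, which places compound 4 beyond the scatter of every other compound shown. The earlier replacement at this same carbonyl carbon, a number 11.7 percentage points higher from compound 1 to compound 3 (beyond the scatter), was modest, so this position can carry a far larger change in the read-out than that step suggested, and the size depends on the group that enters. No measurement given here accounts for the size of this step.

The compounds shown do not tell whether the gain needs the whole (4-methylpiperazin-1-yl)amino group, as a morpholin-4-ylamino or a simple dimethylamino group on the same carbonyl carbon might test. They also leave open whether the group acts the same way with an acetyl rather than a benzoyl on the ring oxygen.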